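Solubility notes on two ortho-substituted anilide cores

The compounds below may be only part of what the source reports. "The series", "measured", "known", "first", "only" and "open" are said of these compounds alone.

Compound 1 `NC(=O)c1ccccc1NC(=O)c1cc2cc([N+](=O)[O-])ccc2o1` and compound 2 `NCc1ccccc1NC(=O)c1cc2cc([N+](=O)[O-])ccc2o1` are built on one core; compound 3 `NC(=O)c1ccccc1NC(=O)c1cc2cc([N+](=O)[O-])ccc2s1` and compound 4 `NCc1ccccc1NC(=O)c1cc2cc([N+](=O)[O-])ccc2s1` are built on another. The difference between the two cores is not broken down here. In a physicochemical assay for solubility (a lower number here means a less soluble compound, a higher number a more soluble compound), compound 1 gives 5 ug/mL, compound 2 gives 5 ug/mL and compound 3 gives 10 ug/mL. The values of compound 3 and compound 1 lie within the scatter of each other, as do those of compound 3 and compound 2. The change from compound 1 to compound 2 is aminomethyl in place of carbamoyl on an aromatic carbon and the step it made was no change at the digits printed from compound 1 to compound 2 (within the scatter). The same change is made from compound 3 to compound 4: aminomethyl in place of carbamoyl on an aromatic carbon. Compound 4 has not yet been measured in this assay. Among the measured compounds shown here, the step from compound 3 to compound 4 is expected to be no change at the digits printed from compound 3 to compound 4 (within the scatter), resting on the step of no change at the digits printed from compound 1 to compound 2 (within the scatter) seen on the first core, the only measured example of this change; the difference between the cores is not broken down, so no further adjustment is made. Compound 4 is therefore estimated at 10 ug/mL, with a range from 4 ug/mL to 25 ug/mL.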

Compound 4, solubility: 1000 ug/mL
The estimate for compound 4 lay 100-fold (2.00 log units) below the measured number; measured number outside the range, above it.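

In this assay the change of aminomethyl in place of carbamoyl gives a 100-fold higher number from compound 3 to compound 4 (2.00 log units; beyond the scatter), whereas the same change on the core of compound 1 gives no change at the digits printed from compound 1 to compound 2 (within the scatter), so the step seen on one core did not carry over to the other in this series. Among the compounds shown here, this shows that the size of the step depends on the core it is made on, but with only two pairs it does not show how the step would behave on any further core, nor which of the two results is the more usual one. Nothing measured here bears on why the two cores part ways.

The compounds shown leave open what a longer aminoethyl chain, a dimethylaminomethyl group or a carboxylic acid in place of carbamoyl would give on either core. They also leave open whether the large step stays when the nitro group on the core of compound 3 is replaced by a nitrile or a methoxy group.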